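The compounds below may be only part of what the source reports. "The series", "measured", "known", "first", "only" and "open" are said of these compounds alone.

Measured compounds in an assay on cells for binding affinity to prostaglandin D2 receptor 2 (Homo sapiens), read by radioligand binding; a lower number here means a stronger inhibitor, a higher number a weaker inhibitor:

compound 1 `Cc1noc(C)c1CN1C(C)(c2c(C)n(CC(=O)O)c3ccccc23)c2ccccc2S1(=O)=O` gives 38 nM
compound 2 `Cc1c(C2c3ccccc3S(=O)(=O)N2CCC(C)C)c2ccccc2n1CC(=O)O` gives 560 nM
compound 3 `O=C(O)Cn1cc(C2c3ccccc3S(=O)(=O)N2Cc2ccccc2)c2ccccc21` gives 1100 nM

Compound 2 sits at the upper end of the three numbers. In this assay compound 2 gives 560 nM, which lies close to compound 3 and within the usual scatter of that value; the gap to compound 1 is large and well beyond the scatter, so compound 2 is clearly a weaker inhibitor than compound 1. Compound 1 also differs at several places at once, so nothing about any single change can be read from it.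

The next compound is compound 4 `Cc1c(C2c3ccccc3S(=O)(=O)N2CCO)c2ccccc2n1CC(=O)O`. Its change from compound 2 is hydroxy in place of isopropyl on a saturated chain carbon, two bonds along the chain from a sulfonamide nitrogen in a ring. For the measured compounds named here, no pair of measured compounds differing at this one place is available, so the size of the effect is not known from the data. Going by the values given here, the chain on the sulfonamide nitrogen is the only part that changes, and the three measured compounds give no direction for it. The expectation is a small shift toward a higher number, about the size of the scatter, from compound 2 to compound 4, a 1.8-fold higher number from compound 2 to compound 4 (0.25 log units; within the scatter). Compound 4 is therefore estimated at 1000 nM, within 300 nM to 3500 nM.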

Compound 4, inhibition constant: 1400 nM
Estimate against measurement, compound 4: 1.4-fold (0.15 log units) below; the measured number falls inside the stated range.
By their numbers in this assay, from the lowest: compound 1; then compounds 2, 3 and 4 (each within the scatter of the next, the first and the last beyond it).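

Hydroxy in place of isopropyl on a saturated chain carbon, two bonds along the chain from a sulfonamide nitrogen in a ring, gives a 2.5-fold higher number from compound 2 to compound 4 (0.40 log units; beyond the scatter) in this assay. For the compounds shown here, this is the first reading of a single change in the chain on the sulfonamide nitrogen: this place responds to the exchange, modestly in size and toward weaker inhibition, and the isopentyl chain is favoured over the 2-hydroxyethyl chain in this one pair. Nothing available explains the step, and no measurement bears on its cause.

Going by these compounds alone, the single pair changes two things together, since three carbons leave while a hydroxy enters, so it cannot say which of them carries the step; a plain ethyl chain, or a methoxy or an amine at the same place, would separate the two. On these data alone, whether the same step holds on the core of compound 1 or of compound 3 also remains open, as does the effect of a longer chain that ends in hydroxy.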